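The source may report more compounds than this note shows. Statements on the series, on what has been measured and on what is new or still open speak of the compounds shown alone.

Measured so far:
compound 1 `O=C(Nc1cc(C(F)(F)F)ccc1N1CCCC1)c1ccncc1` — "not active" (no number reported)
compound 2 `O=C(Nc1cc(C(F)(F)F)ccc1Nc1ccc(Br)cc1)c1cccnc1Cl` — 14200 nM

In a functional assay on HL-60 cells (Homo sapiens) for cytotoxicity, read by MTT assay, with a stated time of 48 h (on this read-out lower numbers stand for stronger inhibition and higher numbers for weaker inhibition), compound 2 gives the only number shown; compound 1 is reported without a single number. Compound 3 `O=C(Nc1cc(C(F)(F)F)ccc1Nc1ccc(Br)cc1)c1ccncc1` is not yet measured. The difference from compound 2 to compound 3 is pyridin-4-yl in place of 2-chloropyridin-3-yl on a carbonyl carbon. Compound 1 already carries pyridin-4-yl on the carbonyl carbon, and in this assay compound 1 gives "not active" (no number reported). The step of a 2.0-fold higher number from compound 2 to compound 3 (0.29 log units; within the scatter) is expected to go toward weaker inhibition, somewhat beyond the usual scatter. Compound 3 is therefore estimated at 28000 nM, with a range from 9000 nM to 90000 nM.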

Compound 3, half-maximal inhibitory concentration: "not active" (no number reported)
Compound 3 has no reported number here, so the estimate cannot be set against anything.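

Within the data shown here, compound 3 has no reported number, and no step from compound 2 to compound 3 can be read; no measured evidence bears on this result. The compounds shown leave open how far pyridin-4-yl in place of 2-chloropyridin-3-yl shifts the read-out.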